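Removing One Trifluoromethyl Group from a Chloroquinoline Stilbene

The compounds below may be only part of what the source reports. "The series", "measured", "known", "first", "only" and "open" are said of these compounds alone.

Measured so far:
Compound 1, `FC(F)(F)c1cccc(/C=C\c2cc3ccccc3nc2Cl)c1`: in a functional assay on MCF7 cells (Homo sapiens) for antiproliferative activity, read by sulforhodamine B assay, with a stated time of 72 h (a lower number here means a stronger inhibitor, a higher number a weaker inhibitor), compound 1 gives 3530 nM.
Compound 2, `FC(F)(F)c1cc(/C=C\c2cc3ccccc3nc2Cl)cc(C(F)(F)F)c1`: in this assay compound 2 gives 7460 nM.
Compound 3, `COc1ccc2nc(Cl)c(/C=C\c3ccc(C(F)(F)F)cc3C(F)(F)F)cc2c1`: in this assay compound 3 reaches only a limit of the assay, > 50000 nM.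

Compounds 1 and 2 share the same core and differ in a single place: hydrogen in place of trifluoromethyl on an aromatic carbon. That change gives a 2.1-fold lower number from compound 2 to compound 1 (0.32 log units; beyond the scatter), a modest gain. Compound 3 carries a different core; the difference between the two cores is not broken down here. Within the data shown here, the only thing known about compound 3 is the limit of > 50000 nM in this assay, at which 1 of the 3 values shown sits, a limit rather than a number.

Compound 4, `COc1ccc2nc(Cl)c(/C=C\c3ccccc3C(F)(F)F)cc2c1`, is not yet measured. It stands to compound 3 as compound 1 stands to compound 2: hydrogen in place of trifluoromethyl on an aromatic carbon. This is the same kind of change, not the same one, since the surroundings differ: in compound 2 the leaving group sits meta to a large group, in compound 3 it sits para to a large group.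

Resting on a 2.1-fold lower number from compound 2 to compound 1 (0.32 log units; beyond the scatter), a similar modest step, an at least 2.0-fold lower number from compound 3 to compound 4 (0.30 log units; that floor lies within the scatter), is expected for compound 4 in this assay. Because compound 3 shows only (the limit of > 50000 nM in this assay, at which 1 of the 3 values shown sits), the starting point is uncertain, so for compound 4 the estimate is 25000 nM, within 8000 nM to 80000 nM.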

Compound 4, half-maximal inhibitory concentration: 4470 nM
Estimate against measurement, compound 4: 5.6-fold (0.75 log units) above; the whole stated range lies above it.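

In this assay, taking away one trifluoromethyl group gives an at least 11-fold lower number from compound 3 to compound 4 (1.04 log units; beyond the scatter), so the change lowers the number on both cores, but its size does not carry over from one core to the other: the same change on two cores in this assay, a 2.1-fold lower number (0.32 log units; beyond the scatter) from compound 2 to compound 1 and an at least 11-fold lower number (1.04 log units; beyond the scatter) from compound 3 to compound 4, at least 5.2-fold (0.72 log units) apart, beyond the scatter of two such steps. The step from compound 3 gives only a floor for the gain, and the real step could be larger, since compound 3 stands at a limit of the assay and not at a number: the limit of > 50000 nM in this assay, at which 1 of the 4 values shown sits. Two pairs do not show what sets the size of the step, whether the rest of the core or the place of the departing group, and they give no rule for predicting it on a further core.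

The compounds shown leave open whether hydrogen is the best replacement, or whether a nitrile or an amine in that place would do as well. They also leave open what happens when the trifluoromethyl group that remains in compound 4 is replaced in the same way.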